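Trimethoxybenzyl ether variant of a piperazine isoxazole series

The compounds below may be only part of what the source reports. "The series", "measured", "known", "first", "only" and "open" are said of these compounds alone.

Measured so far in a functional assay on Huh-7 cells (Homo sapiens) for antiproliferative activity, read by sulforhodamine B assay, with a stated time of 72 h; on this read-out lower numbers stand for stronger inhibition and higher numbers for weaker inhibition:
- compound 1 `Cc1cc(C)cc(COc2ccc(-c3cc(CN4CCN(Cc5ccc(C(F)(F)F)cc5)CC4)no3)cc2)c1` gives 600 nM
- compound 2 `FC(F)(F)c1ccc(CN2CCN(Cc3cc(-c4ccc(OCc5ccc(Cl)cc5)cc4)on3)CC2)cc1` gives 4000 nM
- compound 3 `COc1cccc(COc2ccc(-c3cc(CN4CCN(Cc5ccc(C(F)(F)F)cc5)CC4)no3)cc2)c1` gives 800 nM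

On these three numbers compound 3 stands second highest. Its nearest neighbour is compound 1 a 1.3-fold higher number from compound 1 to compound 3 (0.12 log units; within the scatter), so the two are not distinguishable here; its furthest neighbour is compound 2 a 5.0-fold lower number from compound 2 to compound 3 (0.70 log units; beyond the scatter).

Compound 4 `COc1cc(COc2ccc(-c3cc(CN4CCN(Cc5ccc(C(F)(F)F)cc5)CC4)no3)cc2)cc(OC)c1OC` differs from compound 3 in one place: 3,4,5-trimethoxyphenyl in place of 3-methoxyphenyl on a saturated chain carbon bound to an oxygen on an aromatic ring. The same place has been varied in every measured step. The swap of a 4-chlorophenyl for a 3,5-dimethylphenyl a 6.7-fold higher number from compound 1 to compound 2 (0.82 log units; beyond the scatter) and the reverse-direction swap to 3-methoxyphenyl a 5.0-fold lower number from compound 2 to compound 3 (0.70 log units; beyond the scatter) were both modest and beyond the scatter, while the swap between 3,5-dimethylphenyl and 3-methoxyphenyl a 1.3-fold higher number from compound 1 to compound 3 (0.12 log units; within the scatter) stayed within it. Among the compounds with values here, none of these steps adds methoxy groups to a ring that already carries one, so there is no direct precedent for compound 4. The measured range of this position suggests a step in this assay of modest size at most, with the direction open.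

Compound 4 is therefore estimated to give 1200 nM, with a range from 300 nM to 5000 nM. This corresponds to an expected 1.5-fold higher number from compound 3 to compound 4 (0.18 log units; within the scatter).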

Compound 4, half-maximal inhibitory concentration: 500 nM
Compound 4: middle estimate off by 2.4-fold (0.38 log units), on the high side; low and high end bracket the measured number.
By their numbers in this assay, from the lowest: compounds 4, 1 and 3 (each within the scatter of the next); then compound 2.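

In this assay the position accepts 3,4,5-trimethoxyphenyl, with 12 heavy atoms and 3 hydrogen-bond acceptors against 8 and 1 in 3-methoxyphenyl, without a step beyond the scatter: the change gives a 1.6-fold lower number from compound 3 to compound 4 (0.20 log units; within the scatter) and the comparison with the 3,5-dimethylphenyl ether gives a 1.2-fold lower number from compound 1 to compound 4 (0.08 log units; within the scatter) and so compounds 1, 3 and 4 cannot be told apart. Compound 2 alone stands apart among the four, and the new comparison with its 4-chlorophenyl, an 8.0-fold lower number from compound 2 to compound 4 (0.90 log units; beyond the scatter), is the largest step yet seen at this position. No measurement shown here explains either the shared level of compounds 1, 3 and 4 or the gap to compound 2.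

Going by these compounds, whether a plain phenyl ring, or a ring carrying an amine or a carboxylic acid, would fall with compounds 1, 3 and 4 or with compound 2 stays open. On these data alone, all four compounds keep the rest of the structure unchanged, so it is also open whether this picture would hold with another group in place of the trifluoromethyl.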